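Extending a saturated chain on a shared core

The compounds below may be only part of what the source reports. "The series", "measured", "known", "first", "only" and "open" are said of these compounds alone.

Three compounds that share one core and differ in the length of a saturated chain have been measured in a functional assay on KB cells (Homo sapiens) for cytotoxicity, read by resazurin assay, with a stated time of 3 days (on this read-out lower numbers stand for stronger inhibition and higher numbers for weaker inhibition), so far. Compound 1 (`CCCCCC(=O)NCC(C)(C)CC1=C(O)C(=O)c2ccccc2C1=O`) gives 40200 nM in this test, compound 2 (`CCCCCCC(=O)NCC(C)(C)CC1=C(O)C(=O)c2ccccc2C1=O`) gives 28200 nM and compound 3 (`CCCCCCCCCC(=O)NCC(C)(C)CC1=C(O)C(=O)c2ccccc2C1=O`) gives 18500 nM there.

Compound 2 stands within the scatter of both others. The two steps that touch it are a 1.4-fold lower number from compound 1 to compound 2 (0.15 log units; within the scatter) and a 1.5-fold lower number from compound 2 to compound 3 (0.18 log units; within the scatter) in turn. Only the full span between the outer pair is larger, at a 2.2-fold lower number from compound 1 to compound 3 (0.34 log units; beyond the scatter) as a modest change.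

Compound 4 (`CCCCCCCCCCCC(=O)NCC(C)(C)CC1=C(O)C(=O)c2ccccc2C1=O`) has not yet been measured. Set against compound 2, it carries pentyl in place of hydrogen on a saturated chain carbon, six bonds along the chain from a carbonyl carbon as its change, a pentyl in place of hydrogen at the place where the propyl of compound 3 enters.

Within the data shown here, all three measured steps point the same way, and no compound goes against that, but nothing longer than compound 3 has been tested. A further small move to a lower number is therefore expected, given a 1.5-fold lower number from compound 2 to compound 3 (0.18 log units; within the scatter) for the shorter addition, and the expected step is a 2.0-fold lower number from compound 2 to compound 4 (0.30 log units; within the scatter) in this assay. The estimate for compound 4 is 14000 nM (expected range 7000 nM to 27000 nM).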

Compound 4, half-maximal inhibitory concentration: 12800 nM
For compound 4 the middle estimate is 1.1-fold (0.04 log units) above the measured one; measured number inside the range.
By their numbers in this assay, from the lowest: compounds 4, 3, 2 and 1 (each within the scatter of the next, the first and the last beyond it).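

In this assay, a pentyl in place of hydrogen on a saturated chain carbon, six bonds along the chain from a carbonyl carbon, gives a 2.2-fold lower number from compound 2 to compound 4 (0.34 log units; beyond the scatter) and so at this place the change now passes the scatter, which the shorter propyl did not do. Among these compounds, the full span of the set widens to a 3.1-fold lower number from compound 1 to compound 4 (0.50 log units; beyond the scatter) and this is the largest step among the four compounds, still a modest one, with no compound going against the direction. The last addition taken alone, an ethyl nine bonds along the chain from a carbonyl carbon, gives only a 1.4-fold lower number from compound 3 to compound 4 (0.16 log units; within the scatter) and so the two chains at the long end of the set cannot be told apart in this test.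

Nothing among the data shown offers a reason for this drift with chain length. Going by these compounds, it also stays open whether a longer chain would carry the direction further, or whether an amine or a carboxylic acid on this chain would keep it.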